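The source may report more compounds than this note shows. Statements on the series, on what has been measured and on what is new or still open speak of the compounds shown alone.

Working notes on the series. All four compounds carry the same propenoyl-substituted pyridine bearing a fused bicyclic aryl, and differ in that bicycle and in the group on the carbonyl. In a functional assay on MCF7 cells (Homo sapiens) for inhibition, read by sulforhodamine B assay, with a stated time of 72 h (on this read-out higher numbers stand for weaker inhibition of growth and lower numbers for stronger inhibition of growth), compound 1, `CCOC(=O)/C=C/c1ccncc1-c1ccc2c(ccn2C)c1`, gives 8670 nM, and compound 3, `CNC(=O)/C=C/c1ccncc1-c1ccc2ccccc2c1`, gives 9340 nM; the two lie within the usual scatter of each other. Compound 2, `CNC(=O)/C=C/c1ccncc1-c1ccc2c(cnn2C)c1`, reaches only a limit of this assay, > 10000 nM, so it is one of the values at the limit of > 10000 nM in this assay, at which 1 of the 3 values shown sits, and no number stands for it. Compound 4, `CCOC(=O)/C=C/c1ccncc1-c1ccc2c(cnn2C)c1`, is not yet measured; it differs from compound 2 by ethoxy in place of methylamino on a carbonyl carbon, that is methylcarbamoyl to ethoxycarbonyl. Within the data shown here, no measured pair isolates this change. The step of an at least 1.1-fold lower number from compound 2 to compound 4 (0.04 log units; that floor lies within the scatter) is expected to be small, if anything toward stronger inhibition of growth. Compound 4 is therefore estimated at 9000 nM, within 3000 nM to 30000 nM.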

Compound 4, concentration for 50% growth inhibition: 7320 nM
Beside the measured number, compound 4's estimate is 1.2-fold (0.09 log units) above it; low and high end bracket the measured number.
By their numbers in this assay, from the lowest: compounds 4, 1 and 3 (each within the scatter of the next). At a limit, above all of these: compound 2.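

Among these compounds, this pair is the first to isolate the change: with ethoxy in place of methylamino on a carbonyl carbon, this assay shows an at least 1.3-fold lower number from compound 2 to compound 4 (0.13 log units; that floor lies within the scatter). The change thus brings no move toward weaker inhibition of growth on this core. The value for compound 2 is a limit, so the full size of the step cannot be read: the limit of > 10000 nM in this assay, at which 1 of the 4 values shown sits.

From the compounds shown here alone, whether the same change holds on the other bicycles remains open. Also open, going by these compounds, is what a carboxylic acid, a primary amide or a longer chain such as butoxy would give on this carbonyl carbon.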